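Pyridin-3-ylmethyl in place of 4-methoxybenzyl on the ring nitrogen

The source may report more compounds than this note shows. Statements on the series, on what has been measured and on what is new or still open speak of the compounds shown alone.

Compound 1 `COc1ccc(-n2nc(Nc3cc(C)[nH]n3)c3ccccc3c2=O)cc1` and compound 2 `COc1ccc(Cn2nc(Nc3cc(C)[nH]n3)c3ccccc3c2=O)cc1` share a common core and differ only in the group on the aromatic nitrogen. In a functional assay on HCT-116 cells (Homo sapiens) for cytotoxicity, read by CellTiter-Glo, with a stated time of 5 days (a higher number here means a weaker inhibitor, a lower number a stronger inhibitor), compound 1 gives 700 nM. In this assay compound 2 gives 1200 nM. Among the compounds with values here, the step of a 1.7-fold higher number from compound 1 to compound 2 (0.23 log units; within the scatter) is the only measured step, so compound 2 stands as the higher of two numbers, with compound 1 within the scatter of it; no ordering between the two can be claimed.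

Compound 3 `Cc1cc(Nc2nn(Cc3cccnc3)c(=O)c3ccccc23)n[nH]1` is not yet measured. Relative to compound 2, the change is pyridin-3-yl in place of 4-methoxyphenyl on a saturated chain carbon bound to an aromatic nitrogen. Within the data shown here, no measured step varies the aromatic ring attached to that chain carbon; the one measured step, from compound 1 to compound 2, moved the whole group rather than exchanging the ring, and stayed within the scatter. Nothing in hand therefore points to a step beyond the scatter in this assay in either direction.

For compound 3 the number in this assay is estimated at 1500 nM, with a range of 500 nM to 4500 nM. This estimate means an expected step of a 1.3-fold higher number from compound 2 to compound 3 (0.10 log units; within the scatter).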

Compound 3, half-maximal inhibitory concentration: 2900 nM
Compound 3: middle estimate off by 1.9-fold (0.29 log units), on the low side; the measured number falls inside the stated range.
By their numbers in this assay, from the lowest: compounds 1 and 2 (each within the scatter of the next); then compound 3.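

In this assay, exchanging the ring on a saturated chain carbon bound to an aromatic nitrogen produces a step beyond the scatter: pyridin-3-yl in place of 4-methoxyphenyl gives a 2.4-fold higher number from compound 2 to compound 3 (0.38 log units; beyond the scatter) and so a modestly weaker compound, whereas 4-methoxybenzyl in place of 4-methoxyphenyl gave only a 1.7-fold higher number from compound 1 to compound 2 (0.23 log units; within the scatter) and stayed within it. Measured against the 4-methoxyphenyl group on the aromatic nitrogen, (pyridin-3-yl)methyl gives a 4.1-fold higher number from compound 1 to compound 3 (0.62 log units; beyond the scatter) and is also modestly weaker, so among these three compounds the identity of the ring matters more in this assay than the one chain carbon that separates compound 1 from compound 2. Nothing available explains why the pyridin-3-yl exchange weakens the compound in these cells.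

The exchange removes the methoxy group and places a nitrogen in the ring in a single change, so the two cannot be separated here. An unsubstituted benzyl group, a pyridin-4-ylmethyl group or a longer chain such as 2-(4-methoxyphenyl)ethyl would show which part of the change carries the step and how much room this position allows.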